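From furan-2-yl to 3-fluoropyridin-2-yl on the shared core

The source may report more compounds than this note shows. Statements on the series, on what has been measured and on what is new or still open speak of the compounds shown alone.

Compound 1 (`CN(C)c1ccc2cc(-c3ccccc3)c(N)nc2c1`) gives 4900 nM
Compound 2 (`CN(C)c1ccc2cc(-c3ccco3)c(N)nc2c1`) gives "not determined" (no result reported)

Among the measured compounds shown here, in a toxicity assay on J774.A1 cells (Mus musculus) for cytotoxicity, read by SYBR Green assay, with a stated time of 1 h (a higher number here means that more compound is needed for the effect, a lower number that less compound is needed), compound 1 gives 4900 nM and is the only compound with a number. Compound 2 stands at "not determined" (no result reported) in that measurement, so it offers no value from which to start. Compound 3 (`CN(C)c1ccc2cc(-c3ncccc3F)c(N)nc2c1`) carries 3-fluoropyridin-2-yl in place of furan-2-yl on an aromatic carbon on the shared core. For the measured compounds named here, no measured step shows what such a change does, so the size of the step from compound 2 cannot be read from the data. The expectation therefore rests on compound 1 at 4900 nM alone, with no shift beyond the usual scatter expected in either direction. For compound 3 the estimated value is 5000 nM within an expected range of 2000 nM to 15000 nM in this assay when measured.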

Compound 3, half-maximal effective concentration: 16000 nM
Compound 3: the middle estimate sits 3.2-fold (0.51 log units) below what was measured, and the stated range ends below it.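

In this assay, replacing phenyl with 3-fluoropyridin-2-yl on this aromatic carbon, ortho to an amino group, gives a 3.3-fold higher number from compound 1 to compound 3 (0.51 log units; beyond the scatter) and thus shows that the number responds to the group held at this position. The change takes the number beyond the usual scatter, towards more compound being needed for the effect. Among the compounds shown here, compound 2 has no number, so no step involving it can be read, and furan-2-yl remains unplaced against the other two groups. Nothing measured here accounts for the shift. The compounds shown leave open whether the ring nitrogen or the fluorine carries the step, as the two enter together. They also leave open how plain pyridin-2-yl, or a phenyl bearing an amine or a carboxylic acid, would read at this position.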